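Replacing 2-Chlorophenyl with 1-Benzothiophen-2-yl: An Expected Outcome

This account rests on a few compounds, and the source may have more. Where it says the series, first, only, none or still open, it means among the compounds named here.

Two measured compounds share one core. Compound 1 `COc1ccc(-n2nc(-c3ccccc3)nc2CNc2ccc(C(=O)NO)cc2)cc1` in an assay on Sf9 cells for inhibition of protein deacetylase HDAC6 (Homo sapiens), read by fluorescence, with a stated time of 40 min (on this read-out lower numbers stand for stronger inhibition and higher numbers for weaker inhibition), gives 127 nM. Compound 2 `O=C(NO)c1ccc(NCc2nc(-c3ccccc3Cl)nn2-c2ccccc2)cc1` gives 185 nM, the highest of the two numbers shown, although its gap to compound 1 lies within the scatter. Compound 3 `O=C(NO)c1ccc(NCc2nc(-c3cc4ccccc4s3)nn2-c2ccccc2)cc1` differs from compound 2 by 1-benzothiophen-2-yl in place of 2-chlorophenyl on an aromatic carbon. Among the measured compounds shown here, no step between measured compounds is known, so this change is expected to move this assay by no more than a modest amount, with no clear direction. Compound 3 is expected to give 160 nM, between 50 nM and 500 nM. This is expected to amount to a step of a 1.2-fold lower number from compound 2 to compound 3 (0.06 log units; within the scatter).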

Compound 3, half-maximal inhibitory concentration: 324 nM
The estimate for compound 3 lay 2.0-fold (0.31 log units) below the measured number; the measured number falls inside the stated range.
By their numbers in this assay, from the lowest: compounds 1, 2 and 3 (each within the scatter of the next, the first and the last beyond it).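

Among the compounds shown here, this is the first step read at this position, on an aromatic carbon of a five-membered aromatic ring with 3 nitrogen: in this assay, 1-benzothiophen-2-yl in place of 2-chlorophenyl gives a 1.8-fold higher number from compound 2 to compound 3 (0.24 log units; within the scatter) and so leaves the number within the scatter. Two aromatic rings can therefore stand here in place of one without a step beyond the scatter. Nothing at hand explains this result.

From the compounds shown here alone, whether an amine or a carboxylic acid on this carbon would move the number beyond the scatter remains open.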